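4-Methylthiophen-3-yl in place of 4-methylpyridin-3-yl

The compounds below may be only part of what the source reports. "The series", "measured", "known", "first", "only" and "open" are said of these compounds alone.

Of the compounds shown here, three sharing one core have been measured in a functional assay on MCF7 cells (Homo sapiens) for cytotoxicity, read by CellTiter-Glo, with a stated time of 5 days; a higher number here means a weaker inhibitor, a lower number a stronger inhibitor. Compound 1 `CC/C(=C(/c1ccc(/C=C/C(=O)O)cc1)c1ccc2[nH]ncc2c1)c1ccc(Cl)cc1`, carrying 4-chlorophenyl, gives 15 nM. Compound 2 `CC/C(=C(/c1ccc(/C=C/C(=O)O)cc1)c1ccc2[nH]ncc2c1)c1ccc(C#N)cc1`, carrying 4-cyanophenyl, gives 47 nM. Compound 3 `CC/C(=C(/c1ccc(/C=C/C(=O)O)cc1)c1ccc2[nH]ncc2c1)c1cnccc1C`, carrying 4-methylpyridin-3-yl, gives 150 nM, the highest of the three numbers and so the weakest inhibitor of the set.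

Compound 4 `CC/C(=C(/c1ccc(/C=C/C(=O)O)cc1)c1ccc2[nH]ncc2c1)c1cscc1C` changes that same group, on a double-bonded chain carbon bound to a double-bonded chain carbon and a saturated chain carbon: 4-methylthiophen-3-yl in place of 4-methylpyridin-3-yl on a double-bonded chain carbon bound to a double-bonded chain carbon and a saturated chain carbon.

For the measured compounds named here, two measured steps bear directly on this place: a 10-fold higher number from compound 1 to compound 3 (1.00 log units; beyond the scatter), and a 3.2-fold higher number from compound 2 to compound 3 (0.50 log units; beyond the scatter). A third, a 3.1-fold higher number from compound 1 to compound 2 (0.50 log units; beyond the scatter), shows that the numbers also move when only the group's substituent changes. None of these compounds carries a thiophene, so the data give no direct measure of the incoming group. Compound 3 is, however, the only one with a pyridine, and both steps that introduce it raise the number. Leaving it is therefore expected to recover part of that loss in this assay, though not all of it.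

The expected step is a 3.3-fold lower number from compound 3 to compound 4 (0.52 log units; beyond the scatter), a modest move toward a stronger inhibitor. Compound 4 is estimated at 45 nM, with an expected range of 15 nM to 130 nM.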

Compound 4, half-maximal inhibitory concentration: 2 nM
Compound 4: middle estimate off by 23-fold (1.35 log units), on the high side; the whole stated range lies above it.
By their numbers in this assay, from the lowest: compound 4; then compound 1; then compound 2; then compound 3.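

In this assay, the step to the 4-methylthiophen-3-yl group of compound 4 is far larger than the cost of introducing 4-methylpyridin-3-yl, at a 75-fold lower number from compound 3 to compound 4 (1.88 log units; beyond the scatter), and the same place also gives a 24-fold lower number from compound 2 to compound 4 (1.37 log units; beyond the scatter) and a 7.5-fold lower number from compound 1 to compound 4 (0.88 log units; beyond the scatter). The earlier compounds shown here showed only rises in the number away from the 4-chlorophenyl group of compound 1 at 15 nM, whereas this result shows that a group on this double-bonded chain carbon can go beyond compound 1, and that a five-membered aromatic ring is accepted there in this assay. Nothing available here bears on what lies behind the size of this step.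

The compounds shown do not separate the thiophene ring from its methyl group, since only compound 3 and compound 4 carry a methyl group on the ring at this place, and their rings also differ. From the compounds shown here alone, an unsubstituted thiophen-3-yl, a 4-chlorothiophen-3-yl or a methylphenyl group at this place would bear on that question, and it also stays open whether the gain would hold with an amide in place of the carboxylic acid.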